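Swapping Methyl for Chloro on the Amine Nitrogen

A few compounds are considered here, and "the series" means these few. Any claim that something is new, unique, unknown or untested is made for them only; others in the source may bear on it.

Of the compounds shown here, two sharing one core have been measured in a functional assay on CWR22R cells (Homo sapiens) for cytotoxicity, read by propidium iodide staining, with a stated time of 4 days; a lower number here means a stronger inhibitor, a higher number a weaker inhibitor. Compound 1 `CNC1=CC(=O)c2c(cnc(C)c2C)C1=O` gives 21700 nM. Within the data shown here, compound 2 `CNC1=CC(=O)c2cc(C)ncc2C1=O` gives 4690 nM in this assay, which is the lowest of the two numbers; its only neighbour on this scale is compound 1, a good way higher. Among the measured compounds shown here, the single measured step, a 4.6-fold lower number from compound 1 to compound 2 (0.67 log units; beyond the scatter), arose from hydrogen in place of methyl on an aromatic carbon.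

Compound 3 `Cc1cc2c(cn1)C(=O)C(NCl)=CC2=O` has not yet been measured. It differs from compound 2 in one place: chloro in place of methyl on an amine nitrogen. For the measured compounds named here, the one measured step concerns a ring carbon, not the amine nitrogen, and does not bear on this change; no measured pair shows what chloro in place of methyl on an amine nitrogen does in this assay. With nothing pointing in either direction, the expected step of a 1.0-fold lower number from compound 2 to compound 3 (0.02 log units; within the scatter) is set at none beyond the scatter, with a wide range to allow a larger move either way. Compound 3 is accordingly estimated at 4500 nM in this assay, somewhere between 1000 nM and 20000 nM.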

Compound 3, half-maximal inhibitory concentration: 5670 nM
Compound 3: middle estimate off by 1.3-fold (0.10 log units), on the low side; measured number inside the range.
By their numbers in this assay, from the lowest: compounds 2 and 3 (each within the scatter of the next); then compound 1.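

On the amine nitrogen, chloro in place of methyl gives a 1.2-fold higher number from compound 2 to compound 3 (0.08 log units; within the scatter) in this assay and so, in this one pair, the two groups cannot be told apart by this measurement. Among these compounds, this is the first measured change at the amine nitrogen, and it contrasts with the earlier change on a ring carbon, where hydrogen in place of methyl gave a 4.6-fold lower number from compound 1 to compound 2 (0.67 log units; beyond the scatter) and moved the number beyond the scatter. No measurement at hand explains why this exchange of one heavy atom for another leaves the number within the scatter.

Still open, on these data alone, is whether a different group on this nitrogen, such as an ethyl group, a longer chain or an acetyl group, would leave the number where it is or move it in either direction, and a single pair cannot show how far the present result extends. Also open is whether the step seen on the ring carbon would keep its size with chloro rather than methyl on the amine nitrogen, since the compounds shown hold no pair that tests this.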